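A trifluoromethylphenyl in place of a fluorophenyl

The source may report more compounds than this note shows. Statements on the series, on what has been measured and on what is new or still open speak of the compounds shown alone.

Of the compounds shown here, two of the same series have been measured in a functional assay on MKN-45 cells (Homo sapiens) for cytotoxicity, read by MTT assay, with a stated time of 72 h; on this read-out lower numbers stand for stronger inhibition and higher numbers for weaker inhibition. Compound 1 `COc1cc2c(Oc3ccc(NC(=O)c4cc(-c5ccc(C(F)(F)F)cc5)ccn4)cc3F)ccnc2cc1OCCCN1CCCCC1` gives 870 nM in this assay. Compound 2 `COc1cc2c(Oc3ccc(NC(=O)c4cc(-c5ccccc5F)ccn4)cc3F)ccnc2cc1OCCCN1CCCC1` gives 230 nM in this assay, the lowest of the two numbers; compound 1 stands a good deal higher, and the gap between the two lies beyond the usual scatter. The two differ in two places at once, so the two values show only their overall gap, not what either change contributes.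

Compound 3 `COc1cc2c(Oc3ccc(NC(=O)c4cc(-c5ccc(C(F)(F)F)cc5)ccn4)cc3F)ccnc2cc1OCCCN1CCCC1` has not yet been measured. It differs from compound 2 in one place: 4-(trifluoromethyl)phenyl in place of 2-fluorophenyl on an aromatic carbon. Compound 3 shares its 4-(trifluoromethyl)phenyl group with compound 1 and its three-carbon chain ending in a pyrrolidine with compound 2. A step upward in number, that is weaker inhibition, is expected from compound 2 to compound 3, of the size a 2.6-fold higher number from compound 2 to compound 3 (0.42 log units; beyond the scatter), because compound 1 gives 870 nM with the same aryl group in place. Compound 3 is therefore estimated at 600 nM in this assay, within a range from 200 nM to 1800 nM.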

Compound 3, half-maximal inhibitory concentration: 260 nM
Beside the measured number, compound 3's estimate is 2.3-fold (0.36 log units) above it; measured number inside the range.
By their numbers in this assay, from the lowest: compounds 2 and 3 (each within the scatter of the next); then compound 1.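

Read in this assay the step of a 1.1-fold higher number from compound 2 to compound 3 (0.05 log units; within the scatter) shows that, on the aromatic carbon opposite the ring nitrogen, 2-fluorophenyl and the larger 4-(trifluoromethyl)phenyl cannot be told apart. The overall gap between compound 1 and compound 2 could not be divided before, but compound 3 now ties it to the other end of the molecule: the step of a 3.3-fold lower number from compound 1 to compound 3 (0.52 log units; beyond the scatter) comes with pyrrolidin-1-yl in place of piperidin-1-yl on a saturated chain carbon, three bonds along the chain from an oxygen on an aromatic ring. Nothing given here explains either step.

These compounds leave open whether the aryl position would accept an unsubstituted phenyl, a 4-methoxyphenyl or a pyridyl group as readily, since only two aryl groups are compared here. They also leave open whether pyrrolidin-1-yl would keep its lower number with the 2-fluorophenyl group in place, and how a morpholine, a dimethylamine or a shorter chain would compare with it.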